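Swapping a Phenyl for Trifluoromethyl in a Cyanoacrylamide

The source may hold more compounds than are shown below. What is called first, only, known or untested is meant among the compounds shown, and "the series" means these compounds.

Among the compounds with values here, compound 2 `C[C@H](NC(=O)/C(C#N)=C/c1ccc(-c2ccccc2)cc1)c1ccccc1` holds the higher of the two numbers measured so far: in a functional assay on MM1.S cells (Homo sapiens) for cytotoxicity, read by MTT assay, with a stated time of 72 h, tested at 10 uM (on this read-out lower numbers stand for less inhibition and higher numbers for more inhibition at the one concentration tested (going by the name of the read-out)), compound 2 reaches 49%. Compound 1 `CCCCOc1ccc(/C=C(\C#N)C(=O)N[C@@H](C)c2ccccc2)cc1` gives 31% in this assay. Within the data shown here, the one measured step, a number 18 percentage points higher from compound 1 to compound 2 (beyond the scatter), shows that the group at this position shifts the number by a modest amount. Compound 3 `C[C@H](NC(=O)/C(C#N)=C/c1ccc(C(F)(F)F)cc1)c1ccccc1` differs from compound 2 in a single place: trifluoromethyl in place of phenyl on an aromatic carbon. Among the measured compounds shown here, no measured step covers trifluoromethyl here, so the direction is uncertain; a modest loss is expected, giving an expected step of a number 14 percentage points lower from compound 2 to compound 3 (beyond the scatter). Compound 3 is estimated at 35%, within 15% to 55%.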

Compound 3, a percentage reported as inhibition, at one concentration (the size of the read-out at that concentration, not a potency): 63%
Compound 3: the middle estimate sits 28 percentage points below what was measured; the whole stated range lies below it.
By their numbers in this assay, from the lowest: compound 1; then compound 2; then compound 3.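

In this assay, trifluoromethyl in place of phenyl gives a number 14 percentage points higher from compound 2 to compound 3 (beyond the scatter), and trifluoromethyl in place of butoxy gives a number 32 percentage points higher from compound 1 to compound 3 (beyond the scatter). A second aromatic ring at this position is therefore not needed for a higher number: of the three groups compared here, trifluoromethyl, which has no ring, ranks highest. Nothing available here explains this order. Still open, on these data alone, is how an amine or a carboxylic acid at this position would compare. As far as these compounds go, whether trifluoromethyl keeps its lead with a different group on the amide nitrogen also remains unknown.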